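Amino in place of hydroxy on an aromatic carbon

This account rests on a few compounds, and the source may have more. Where it says the series, first, only, none or still open, it means among the compounds named here.

In an ADME assay on MT4 cells (Homo sapiens) for cytotoxicity, read by MTT assay (a higher number here means that more compound is tolerated, a lower number that less compound is tolerated), compound 1 `Cc1cc(C)cc(S(=O)(=O)c2c(C(=O)Nc3cccc(O)c3)[nH]c3ccc(Cl)cc23)c1` gives 24600 nM and compound 2 `Cc1cc(C)cc(S(=O)(=O)c2c(C(=O)NCc3ccccc3O)[nH]c3ccc(Cl)cc23)c1` gives 23800 nM, so compound 2 stands level with compound 1 within the scatter. Compound 3 `Cc1cc(C)cc(S(=O)(=O)c2c(C(=O)NCc3ccccc3N)[nH]c3ccc(Cl)cc23)c1` differs from compound 2 in one group: amino in place of hydroxy on an aromatic carbon. This is amino in place of hydroxy on an aromatic carbon, ortho to a large group. Going by the values given here, no measured pair shows this exchange directly. Among the compounds with values here, the one measured step is a different change, 2-hydroxybenzyl in place of 3-hydroxyphenyl on an amide-type nitrogen, and it offers only indirect guidance: a 1.0-fold lower number from compound 1 to compound 2 (0.01 log units; within the scatter). On that single step, no shift beyond the scatter is expected in this assay, and no direction is favoured. The expected step is a 1.1-fold lower number from compound 2 to compound 3 (0.03 log units; within the scatter). The estimate for compound 3 is 22000 nM, with an expected range of 9000 nM to 50000 nM.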

Compound 3, half-maximal cytotoxic concentration: 46200 nM
Compound 3: the middle estimate sits 2.1-fold (0.32 log units) below what was measured; the measured number falls inside the stated range.
By their numbers in this assay, from the lowest: compounds 2, 1 and 3 (each within the scatter of the next).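

In this assay, going by these compounds alone, the first direct reading of amino in place of hydroxy, on an aromatic carbon ortho to a large group, gives a 1.9-fold higher number from compound 2 to compound 3 (0.29 log units; within the scatter) and so places compound 3 level with compound 2. The 2-aminobenzyl group in place of 3-hydroxyphenyl on an amide-type nitrogen gives a 1.9-fold higher number from compound 1 to compound 3 (0.27 log units; within the scatter) and so adds compound 1 to the same picture: among these three compounds, neither exchange moves the number beyond the scatter. Nothing available explains either step.

The compounds shown leave open whether a methoxy group, a dimethylamino group or a carboxylic acid on this same aromatic carbon would also stand level with hydroxy and amino. They also leave open whether amino would read the same way on the 3-hydroxyphenyl group of compound 1, as a 3-aminophenyl group.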